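The source may report more compounds than this note shows. Statements on the series, on what has been measured and on what is new or still open speak of the compounds shown alone.

Antiproliferative data in a functional assay on VCaP cells (Homo sapiens) for antiproliferative activity, read by propidium iodide staining, with a stated time of 96 h; on this read-out higher numbers stand for weaker inhibition and lower numbers for stronger inhibition:

compound 1, `CC(O)(CSc1ccc(C(F)(F)F)cc1)C(=O)Nc1ccc(S(F)(F)(F)(F)F)cc1`: 24800 nM
compound 2, `CC(O)(CSc1ccc(OC(F)(F)F)cc1)C(=O)Nc1ccc(S(F)(F)(F)(F)F)cc1`: 16000 nM
compound 3, `CC(O)(CSc1cccc(C(F)(F)F)c1)C(=O)Nc1cccc(S(F)(F)(F)(F)F)c1`: 20200 nM

Compound 1 and compound 2 differ by trifluoromethoxy in place of trifluoromethyl on an aromatic carbon, a change that gave a 1.6-fold lower number from compound 1 to compound 2 (0.19 log units; within the scatter). Compound 3 shares its atoms with compound 1 but joined differently; the difference between the two cores is not broken down here. Compound 4, `CC(O)(CSc1cccc(OC(F)(F)F)c1)C(=O)Nc1cccc(S(F)(F)(F)(F)F)c1`, is not yet measured and differs from compound 3 by trifluoromethoxy in place of trifluoromethyl on an aromatic carbon. This is the same kind of change as that from compound 1 to compound 2, but the place differs: para to a large group in compound 1, meta to a large group in compound 3. Given that the earlier change gave a 1.6-fold lower number from compound 1 to compound 2 (0.19 log units; within the scatter), the step from compound 3 to compound 4 is expected to be of similar size, a 1.6-fold lower number from compound 3 to compound 4 (0.19 log units; within the scatter), and well within the scatter. Compound 4 is therefore estimated at 13000 nM in this assay, with a likely range from 6000 nM to 28000 nM.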

Compound 4, half-maximal inhibitory concentration: 17500 nM
Beside the measured number, compound 4's estimate is 1.3-fold (0.13 log units) below it, and the stated range covers the measured number.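

In this assay, trifluoromethoxy in place of trifluoromethyl gave a 1.2-fold lower number from compound 3 to compound 4 (0.06 log units; within the scatter). Set beside the earlier step, the change behaves alike on the two cores, with no difference that can be told from noise: the same change on two cores in this assay, a 1.6-fold lower number (0.19 log units; within the scatter) from compound 1 to compound 2 and a 1.2-fold lower number (0.06 log units; within the scatter) from compound 3 to compound 4, 1.3-fold (0.13 log units) apart, within the scatter of two such steps. Among these compounds, this shows only that the change stayed within the scatter on both cores; it does not establish a real effect of the change on either core, and two pairs say nothing about a third core.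

The compounds shown leave open whether another group on that aromatic carbon, such as a nitrile, a chlorine atom or an amine, would shift the number beyond the scatter. Also open, on these data alone, is how a carboxylic acid there would read in this assay.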